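Chloro to Bromo on Two Related Benzimidazole-Thioether Cores

A few compounds are considered here, and "the series" means these few. Any claim that something is new, unique, unknown or untested is made for them only; others in the source may bear on it.

Two pairs of compounds share the same small change. Compound 1 `Cc1cc(C)cc(Cn2c(SCC(=O)Nc3ccccc3Cl)nc3ccccc32)c1` and compound 3 `Cc1cc(C)cc(Cn2c(SCC(=O)Nc3ccccc3Br)nc3ccccc32)c1` differ by bromo in place of chloro on an aromatic carbon. Compound 2 `Cc1cc(C)cc(S(=O)(=O)n2c(SCC(=O)Nc3ccccc3Cl)nc3ccccc32)c1` and compound 4 `Cc1cc(C)cc(S(=O)(=O)n2c(SCC(=O)Nc3ccccc3Br)nc3ccccc32)c1` differ in the same way, by bromo in place of chloro on an aromatic carbon. How the core of compound 1 differs from the core of compound 2 is not broken down here.

In an ADME assay on MT4 cells (Homo sapiens) for cytotoxicity (a lower number here means that less compound is tolerated, a higher number that more compound is tolerated), compound 1 gives 111000 nM. In this assay compound 2 gives 107000 nM, and these two numbers lie within the usual scatter of each other. For compound 3 the result in this assay is a limit, >= 143000 nM, so the number is not known exactly. The measured step is therefore an at least 1.2-fold higher number from compound 1 to compound 3 (0.11 log units; that floor lies within the scatter).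

Compound 4 has not yet been measured in this assay. The same change from compound 2 is expected to give a step of a 1.2-fold higher number from compound 2 to compound 4 (0.08 log units; within the scatter), resting on the step seen from compound 1 to compound 3, with the limit of >= 143000 nM in this assay, at which 1 of the 3 values shown sits, leaving room for a result that again comes out as a limit. Compound 4 is thus estimated at 130000 nM, within 70000 nM to 260000 nM.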

Compound 4, half-maximal cytotoxic concentration: >= 235000 nM
Compound 4: no number, only a limit; the forecaster's own chance of this, stated with the estimate: 40%; at least 1.8-fold (0.25 log units) between middle value and limit.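

For compound 4 the result in this assay is >= 235000 nM, which is a limit and not an exact number. Bromo in place of chloro gives an at least 2.1-fold higher number from compound 2 to compound 4 (0.34 log units; beyond the scatter), so on this core the change clearly allows more compound to be tolerated, although the full size of the step stays unknown. Neither core shows a drop with this change, but only a floor is known for each step, so the data do not show that the change carries from one core to the other with the same size: the same change on two cores in this assay, an at least 1.2-fold higher number (0.11 log units; that floor lies within the scatter) from compound 1 to compound 3 and an at least 2.1-fold higher number (0.34 log units; beyond the scatter) from compound 2 to compound 4; the limit leaves it open whether they differ.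

The compounds shown carry only chloro or bromo on this aromatic carbon, so it remains open how another group there, such as fluoro, methoxy or a carboxylic acid, would behave in this assay. On these data alone, the results for compound 3 and compound 4 are both limits, so their exact numbers, and any real difference between the two steps, also remain open.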